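Working notes: nitro added to compound 2

The compounds below may be only part of what the source reports. "The series", "measured", "known", "first", "only" and "open" are said of these compounds alone.

Compound 1 `Cn1c(C(F)(F)F)nc2cc(Cl)c(Cl)cc21`: 39000 nM
Compound 2 `FC(F)(F)c1nc2cc(Cl)c(Cl)cc2n1Cc1ccccc1`: 8700 nM
Compound 3 `O=[N+]([O-])c1ccccc1Cn1c(C(F)(F)F)nc2cc(Cl)c(Cl)cc21`: 1500 nM

In a functional assay on MCF7 cells (Homo sapiens) for cytotoxicity, read by MTT assay, with a stated time of 48 h (on this read-out lower numbers stand for stronger inhibition of growth and higher numbers for weaker inhibition of growth), compound 2 gives 8700 nM, the second highest of the three numbers. The next structure to be tested is compound 4 `O=[N+]([O-])c1ccc(Cn2c(C(F)(F)F)nc3cc(Cl)c(Cl)cc32)cc1`, and its difference from compound 2 is counted as follows: nitro in place of hydrogen on an aromatic carbon. The change is nitro in place of hydrogen on an aromatic carbon, of a six-membered aromatic ring of carbon only, para to a large group.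

The closest measured precedent is a 5.8-fold lower number from compound 2 to compound 3 (0.76 log units; beyond the scatter). This is the same kind of change, a nitro in place of hydrogen on an aromatic carbon, and it lies beyond the scatter. The other measured step, a 4.5-fold lower number from compound 1 to compound 2 (0.65 log units; beyond the scatter), places phenyl in place of hydrogen on a saturated chain carbon bound to an aromatic nitrogen, so it bears on the present change only loosely. It shows that the number in this assay has moved once already with a change at this part of the series.

Within the data shown here, one precedent is thin support, so a modest step toward a lower number is expected, probably somewhat smaller than the one seen with compound 3. The estimated step is a 3.5-fold lower number from compound 2 to compound 4 (0.54 log units; beyond the scatter). The estimate for compound 4 is 2500 nM, with an expected range of 800 nM to 7000 nM.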

Compound 4, concentration for 50% growth inhibition: 97300 nM
Compound 4: middle estimate off by 39-fold (1.59 log units), on the low side; the measured number lies above the stated range.
By their numbers in this assay, from the lowest: compound 3; then compound 2; then compound 1; then compound 4.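

In this assay nitro in place of hydrogen on an aromatic carbon does not carry one direction through the series: a 5.8-fold lower number from compound 2 to compound 3 (0.76 log units; beyond the scatter) but an 11-fold higher number from compound 2 to compound 4 (1.05 log units; beyond the scatter) when the nitro stands para to a large group. Compound 3 and compound 4 hold the same groups and differ only in which carbon of the ring bears the nitro, so the carbon chosen decides the direction of the step, and one precedent with this group could not be carried over to another carbon of the ring. Nothing available here accounts for the reversal.

As far as these compounds go, whether the rise belongs to nitro itself or to any group placed on this carbon remains open, and an amine or a carboxylic acid para to a large group would test that on the same benzyl-type side chain of compound 2. From the compounds shown here alone, the other carbons of the ring also remain open, so two nitro placements fix no trend around it.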